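Shortening the Chain and Swapping Hydroxyl for Amine

A few compounds are considered here, and "the series" means these few. Any claim that something is new, unique, unknown or untested is made for them only; others in the source may bear on it.

Measured compounds:
- compound 1 `Cc1cn(C2CC(N=[N+]=[N-])C(COC(=O)OCCO)O2)c(=O)[nH]c1=O`: -1.2
- compound 2 `Cc1cn(C2CC(N=[N+]=[N-])C(COC(=O)NCCCO)O2)c(=O)[nH]c1=O`: -1.24
- compound 3 `Cc1cn(C2CC(N=[N+]=[N-])C(COC(=O)OCCCCO)O2)c(=O)[nH]c1=O`: -0.68

In a physicochemical assay for lipophilicity (a lower number here means a more polar compound, a higher number a more lipophilic compound), compound 3 stands highest of the three, with a number 0.52 log units higher from compound 1 to compound 3 (beyond the scatter) and a number 0.56 log units higher from compound 2 to compound 3 (beyond the scatter) separating it from the others. Compound 4 `Cc1cn(C2CC(N=[N+]=[N-])C(COC(=O)OCCCN)O2)c(=O)[nH]c1=O` differs from compound 3 by amino in place of hydroxymethyl on a saturated chain carbon, three bonds along the chain from an oxygen next to a carbonyl group. For the measured compounds named here, no measured pair shows a hydroxyl-to-amine exchange, so the only guide is the chain step a number 0.52 log units higher from compound 1 to compound 3 (beyond the scatter), where a longer hydroxylated chain gave a modestly higher value. Compound 4 carries a shorter chain than compound 3, so the expectation is a modest fall, a number 0.72 log units lower from compound 3 to compound 4 (beyond the scatter), back toward the values of compounds 1 and 2. Compound 4 is therefore estimated at -1.4, in a range from -2.2 to -0.7.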

Compound 4, partition coefficient: -0.93
Beside the measured number, compound 4's estimate is 0.47 log units below it, and the stated range covers the measured number.
By their numbers in this assay, from the lowest: compounds 2, 1, 4 and 3 (each within the scatter of the next, the first and the last beyond it).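

In this assay, amino in place of hydroxymethyl on this saturated chain carbon gives a number 0.25 log units lower from compound 3 to compound 4 (within the scatter), so this exchange can't be told apart from the scatter. Aminomethyl in place of hydroxy gives a number 0.27 log units higher from compound 1 to compound 4 (within the scatter), also inside the scatter, whereas 3-aminopropoxy in place of (3-hydroxypropyl)amino on the carbonyl carbon gives a number 0.31 log units higher from compound 2 to compound 4 (beyond the scatter), a modest step. Nothing available explains these steps. From the compounds shown here alone, it remains open how a longer chain ending in amino, or a carboxylic acid at the chain end, would read in this assay.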